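This account rests on a few compounds, and the source may have more. Where it says the series, first, only, none or still open, it means among the compounds named here.

Compounds measured so far in a functional assay on K562 cells for agonist activity at integrin alpha-M/beta-2 (Homo sapiens); on this read-out lower numbers stand for an effect already at smaller amounts and higher numbers for an effect only at larger amounts of compound:
- compound 1, `CCOC(=O)CN1C(=O)S/C(=C\c2ccc(N3CCCC3)o2)C1=O`: 23200 nM
- compound 2, `CCOC(=O)CN1C(=O)S/C(=C\c2ccc(-c3ccccc3)o2)C1=O`: 10500 nM

Compound 2 is the lower of these two numbers; compound 1 lies a 2.2-fold lower number from compound 1 to compound 2 (0.34 log units; beyond the scatter) away, a step that is outside the usual scatter. That step concerns a different part of the molecule, phenyl in place of pyrrolidin-1-yl on an aromatic carbon, and so says nothing about the change considered here.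

Compound 3, `Cc1cccc(NC(=O)CN2C(=O)S/C(=C\c3ccc(-c4ccccc4)o3)C2=O)c1`, differs from compound 2 in one place: (3-methylphenyl)amino in place of ethoxy on a carbonyl carbon. For the measured compounds named here, no measured pair shows what happens when the ethoxy on the carbonyl carbon is exchanged in this way, and no step in this assay bears on it. There is therefore no basis on the numbers at hand for expecting the number to move in either direction beyond the scatter.

For compound 3 in this assay the estimated value is 9000 nM, with a range from 2000 nM to 35000 nM; this estimate amounts to an expected step of a 1.2-fold lower number from compound 2 to compound 3 (0.07 log units; within the scatter). The range is wide: nothing measured speaks to this change.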

Compound 3, half-maximal effective concentration: 22300 nM
The estimate for compound 3 lay 2.5-fold (0.39 log units) below the measured number, within the range that was stated.
By their numbers in this assay, from the lowest: compound 2; then compounds 3 and 1 (each within the scatter of the next).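

In this assay, for the compounds shown here, replacing the ethoxy on the carbonyl carbon with (3-methylphenyl)amino gives a 2.1-fold higher number from compound 2 to compound 3 (0.33 log units; beyond the scatter), the first reading of any change at this position. The step is modest but beyond the scatter, so the number does respond to what sits on this carbonyl carbon, and here the larger group, with its six-membered aromatic ring and hydrogen-bond donor, moves it upward rather than down. No measurement at hand explains this step.

The compounds shown leave open which part of the entering group goes with the step: the nitrogen in place of the oxygen, the aromatic ring, or the methyl on that ring. Phenylamino without the methyl, a small methylamino group or a free carboxylic acid on the same carbonyl carbon would help to separate these parts, and it also remains open whether the exchange would give a similar step with pyrrolidin-1-yl in place of the phenyl.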